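Replacing a piperazine amide on a spirocyclic cholesterol transporter binder

The source may hold more compounds than are shown below. What is called first, only, known or untested is meant among the compounds shown, and "the series" means these compounds.

Measured so far:
- compound 1 `CC(C)(C)c1ccc(C(=O)N2CCC3(CC2)C(=O)N(CC(=O)N2CCNCC2)CN3c2ccccc2)cc1`: 22000 nM
- compound 2 `CC(C)(C)OC(=O)NC1CCN(C(=O)CN2CN(c3ccccc3)C3(CCN(C(=O)c4ccc(C5CCCCC5)cc4)CC3)C2=O)CC1`: 4800 nM
- compound 3 `CCc1nn(CC)c(C2CCN(C(=O)CN3CN(c4ccccc4)C4(CCN(C(=O)c5ccc(C6CCCCC6)cc5)CC4)C3=O)CC2)c1C`: "not determined" (no result reported)

In an assay on HEK293 cells for displacement of a labelled ligand from NPC1-like intracellular cholesterol transporter 1 (Homo sapiens) (a lower number here means a stronger inhibitor, a higher number a weaker inhibitor), compound 1 gives 22000 nM, the higher of the two numbers available, so it is the weaker inhibitor of the pair. Compound 2 gives 4800 nM, and the gap between the two lies beyond the usual scatter; since compound 2 differs from compound 1 in more than one place, the data give no cause for that gap. In this assay compound 3 gives "not determined" (no result reported), so no number is available for it.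

Compound 4 `CC(C)(C)c1ccc(C(=O)N2CCC3(CC2)C(=O)N(CC(=O)N2CCC(CCO)CC2)CN3c2ccccc2)cc1` is not yet measured. It differs from compound 1 in one place: 4-(2-hydroxyethyl)piperidin-1-yl in place of piperazin-1-yl on a carbonyl carbon. The group that leaves is piperazin-1-yl, the group that enters is 4-(2-hydroxyethyl)piperidin-1-yl, both on a carbonyl carbon whose other neighbour is a saturated chain carbon.

Among the compounds with values here, no measured step of this kind exists here, so the expectation is a small change, if any beyond the scatter, leaning toward a lower number. Compound 4 is expected to give 12000 nM, within 3500 nM to 40000 nM. This amounts to an expected step of a 1.8-fold lower number from compound 1 to compound 4 (0.26 log units; within the scatter).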

Compound 4, half-maximal inhibitory concentration: 2600 nM
Compound 4: the middle estimate sits 4.6-fold (0.66 log units) above what was measured, and the stated range ends above it.
By their numbers in this assay, from the lowest: compounds 4 and 2 (each within the scatter of the next); then compound 1.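

Within the data shown here, this is the first pair that differs in one place only, so the change can be read directly: in this assay, putting 4-(2-hydroxyethyl)piperidin-1-yl in place of piperazin-1-yl gives an 8.5-fold lower number from compound 1 to compound 4 (0.93 log units; beyond the scatter) and this step lies beyond the usual scatter. It shows that binding responds to the group on this carbonyl carbon, and that piperazin-1-yl can be exchanged here without weakening inhibition. The available data offer no measured explanation for the size or direction of this step.

The exchange alters the ring and adds a 2-hydroxyethyl chain in a single step, so the contribution of each remains unresolved. Going by these compounds, it also remains open how plain piperidin-1-yl or 4-(2-aminoethyl)piperidin-1-yl, which carries an amine instead of the alcohol, would compare.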